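This account rests on a few compounds, and the source may have more. Where it says the series, first, only, none or still open, it means among the compounds named here.

Working notes on the series. Two analogues share the core and have been run in an assay on CHO cells for displacement of a labelled ligand from histamine receptor H3 (Macaca mulatta); on this read-out higher numbers stand for weaker inhibition and lower numbers for stronger inhibition. Compound 1 `Cc1cc(N2CCC(N3CCCC3C)C2)ccc1NC(=O)C1CC2CCC1C2` gives 19.9 nM in this assay. Compound 2 `CC1CCCN1C1CCN(c2ccc(NC(=O)C3CCCO3)cc2)C1` gives 8.7 nM in this assay, the lowest of the two numbers, with compound 1 the nearest and carrying a higher number beyond the usual scatter. Compound 1 and compound 2 differ in more than one place, so their two values alone say nothing about any single change.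

Compound 3 `Cc1cc(N2CCC(N3CCCC3C)C2)ccc1NC(=O)C1CCCO1` is not yet measured. The change from compound 2 to compound 3 is methyl in place of hydrogen on an aromatic carbon. Going by the values given here, no measured pair in the set isolates this change, so no step can anchor it; the expectation is for no step beyond the scatter, in either direction. Compound 3 is therefore estimated at 11 nM in this assay, with a range from 5 nM to 28 nM, which corresponds to an expected step of a 1.3-fold higher number from compound 2 to compound 3 (0.10 log units; within the scatter).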

Compound 3, inhibition constant: 7.34 nM
Compound 3: middle estimate off by 1.5-fold (0.18 log units), on the high side; measured number inside the range.
By their numbers in this assay, from the lowest: compounds 3 and 2 (each within the scatter of the next); then compound 1.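

In this assay, going by these compounds alone, methyl in place of hydrogen on the aromatic carbon ortho to the ((oxolan-2-yl)carbonyl)amino group gives a 1.2-fold lower number from compound 2 to compound 3 (0.07 log units; within the scatter) and so leaves the read-out within the scatter, the first direct reading of this position. With that methyl present in both compounds, the group on the carbonyl carbon can also be read alone: the group of 5 heavy atoms with one five-membered non-aromatic ring in place of the group of 7 heavy atoms with 2 five-membered non-aromatic rings gives a 2.7-fold lower number from compound 1 to compound 3 (0.43 log units; beyond the scatter) as a modest step. No supporting data bear on the reason for either step.

Open, as far as these compounds go, is whether ethyl, methoxy or chlorine on this aromatic carbon would also stay within the scatter of compound 2. Also open, from the compounds shown here alone, is whether methyl would give a similar step with the group of 7 heavy atoms on the carbonyl carbon.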